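Swapping fluoro for methoxy on an aromatic carbon

A few compounds are considered here, and "the series" means these few. Any claim that something is new, unique, unknown or untested is made for them only; others in the source may bear on it.

In a functional assay on V79 cells (Cricetulus griseus) for cytotoxicity, read by colony formation (on this read-out lower numbers stand for stronger inhibition and higher numbers for weaker inhibition), compound 3 `NC1CCCN(c2c(F)cc3c(=O)c(C(=O)O)cn(C4CC4)c3c2F)C1` gives 53 ug/mL as its result. That is a lower number than compound 2 `CNCC1(C)CCN(c2c(F)cc3c(=O)c(C(=O)O)cn(C4CC4)c3c2OC)C1` with 120 ug/mL in the same test, and the gap lies beyond the usual scatter of repeated measurements. Compound 1 `CCNCC1CCN(c2c(F)cc3c(=O)c(C(=O)O)cn(C4CC4)c3c2OC)C1` gives 22 ug/mL; 22 ug/mL (2 entries) across its two measurements.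

Compound 4 `COc1c(N2CCCC(N)C2)c(F)cc2c(=O)c(C(=O)O)cn(C3CC3)c12` has not been measured yet. It differs from compound 3 in one place methoxy in place of fluoro on an aromatic carbon and has methoxy in place of fluoro on an aromatic carbon, ortho to a 3-aminopiperidin-1-yl group.

Within the data shown here, no measured pair shows this swap on its own. Compound 1 at 22 ug/mL; 22 ug/mL (2 entries) and compound 2 at 120 ug/mL both carry methoxy where compound 3 has fluoro, but they also differ from it elsewhere. Their numbers fall on either side of the result for compound 3, so they point to no clear direction. The expectation is therefore a small move, with a slight lean towards a higher number, meaning weaker inhibition. The estimated change is a 1.2-fold higher number from compound 3 to compound 4 (0.09 log units; within the scatter) and would stay within the scatter. In this assay compound 4 is estimated at 65 ug/mL with an expected range running from 25 ug/mL to 170 ug/mL around that middle.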

Compound 4, half-maximal inhibitory concentration: 69 ug/mL
Estimate against measurement, compound 4: 1.1-fold (0.03 log units) below; measured number inside the range.
By their numbers in this assay, from the lowest: compounds 3, 4 and 2 (each within the scatter of the next, the first and the last beyond it).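

In this assay, among these compounds, the swap of methoxy in place of fluoro on an aromatic carbon, ortho to a 3-aminopiperidin-1-yl group, can now be read on its own as a 1.3-fold higher number from compound 3 to compound 4 (0.11 log units; within the scatter) and so stays within the scatter, which the earlier compounds could not show because each differed from compound 3 in more than one place. With methoxy held constant, the exchange of 3-aminopiperidin-1-yl in place of 3-methyl-3-((methylamino)methyl)pyrrolidin-1-yl appears as a 1.7-fold lower number from compound 2 to compound 4 (0.24 log units; within the scatter) and is also within the scatter, so neither single change on its own gives a clear shift on this read-out. No measurement shown here offers an explanation for either step.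

The compounds shown carry only fluoro or methoxy on this aromatic carbon, so what a chloro or an ethoxy group would give there remains open. As far as these compounds go, whether the swap of methoxy in place of fluoro would read the same alongside the side groups of compound 1 and compound 2 also remains open.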